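A few compounds are considered here, and "the series" means these few. Any claim that something is new, unique, unknown or untested is made for them only; others in the source may bear on it.

Of the compounds shown here, three have been tested in a functional assay on DLD-1 cells (Homo sapiens) for antiproliferative activity, read by CellTiter-Glo, with a stated time of 72 h; a lower number here means a stronger inhibitor, a higher number a weaker inhibitor. Compound 1 `CC1CCN(C2CCN(S(=O)(=O)c3cccc(C(F)(F)F)c3)CC2)CC1` gives only the assay's limit, > 5000 nM, and no number. Compound 2 `Cc1noc(C)c1S(=O)(=O)N1CCC(N2CCC(C)CC2)CC1` likewise stops at a limit, > 5000 nM. Compound 3 `CCc1cc(Br)ccc1S(=O)(=O)N1CCC(N2CCC(C)CC2)CC1` gives 0.6 nM. Compound 2 therefore stands at the limit of > 5000 nM in this assay, at which 2 of the 3 values shown sit, so its own potency is not known beyond that boundary.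

Compound 4 `CC1CCN(C2CCN(S(=O)(=O)c3ccccc3Br)CC2)CC1` differs from compound 2 in one place: 2-bromophenyl in place of 3,5-dimethyl-1,2-oxazol-4-yl on a sulfonyl sulfur, on a sulfonyl sulfur whose other neighbour is the sulfonamide nitrogen in a ring. Within the data shown here, no measured step of this kind is available, so the size of the change is open. The expected step of an at least 25-fold lower number from compound 2 to compound 4 (1.39 log units; beyond the scatter) is toward stronger inhibition, beyond the scatter but with wide uncertainty. Compound 4 is estimated at 200 nM, somewhere between 5 nM and 5000 nM.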

Compound 4, half-maximal inhibitory concentration: 3 nM
Estimate against measurement, compound 4: 67-fold (1.82 log units) above; measured number outside the range, below it.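

In this assay the change of group on the sulfonyl sulfur, an at least 1600-fold lower number from compound 2 to compound 4 (3.22 log units; beyond the scatter), shows that this one position can separate a compound with no measurable potency from a strong inhibitor. The shared core alone is therefore not enough for activity. From the compounds shown here alone, the true size of the step remains unknown because compound 2 has only a limit: the limit of > 5000 nM in this assay, at which 2 of the 4 values shown sit.

Going by these compounds, what remains open is whether the bromine itself matters or any phenyl ring would serve. A plain phenyl, or a chlorine or methoxy group on that ring, could answer this.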